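Half-life in Liver Microsomes: Replacing a Thiazolylamino Group

This account rests on a few compounds, and the source may have more. Where it says the series, first, only, none or still open, it means among the compounds named here.

Measured compounds:
compound 1 `CC(C)C(Nc1nccs1)c1ccc(-c2ccc3cccc(F)c3c2)[nH]c1=O`: 0.17 h
compound 2 `CC(C)[C@H](C[C@H]1CCNC1=O)c1ccc(-c2ccc3cccc(F)c3c2)[nH]c1=O`: 0.257 h

In an ADME assay on microsomes from liver (Homo sapiens) for metabolic stability (a higher number here means that the compound lasts longer, a lower number that the compound disappears faster), compound 1 gives 0.17 h, the smaller of the two numbers, while compound 2 gives 0.257 h; the gap between them lies within the usual scatter, so the two cannot be told apart. Compound 3 `CC(C)C(CC(N)=O)c1ccc(-c2ccc3cccc(F)c3c2)[nH]c1=O` has not yet been measured. It differs from compound 1 by carbamoylmethyl in place of (1,3-thiazol-2-yl)amino on a saturated chain carbon bound to an aromatic carbon and a saturated chain carbon. Within the data shown here, no measured pair shows this kind of change, so the size of the step can only be guessed from the two numbers at hand, both of which are short. In this assay the step of a 1.5-fold higher number from compound 1 to compound 3 (0.17 log units; within the scatter) is expected to be small, probably not beyond the scatter, with at most a slight lean upward. Compound 3 is therefore estimated at 0.25 h, with a likely range from 0.1 h to 0.6 h.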

Compound 3, half-life: < 0.0667 h
Compound 3 ended at the assay's limit (the forecaster's own chance of this, stated with the estimate: 5%); middle value at least 3.7-fold (0.57 log units) away from the limit.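

In this assay compound 3 gives < 0.0667 h, which is a limit of the assay and not a number: the limit of < 0.0667 h in this assay, at which 1 of the 3 values shown sits.

Even so, carbamoylmethyl in place of (1,3-thiazol-2-yl)amino on this saturated chain carbon gives an at least 2.5-fold lower number from compound 1 to compound 3 (0.40 log units; beyond the scatter), so the true size of the step remains open on the low side. Among these compounds, this is the first single change at this position to be read, and it shows that the half-life depends on the group placed there, which compound 1 and compound 2 could not show, as those two cannot be told apart.

On these data alone, how far compound 3 lies past the limit remains unknown, as does whether the drop follows from losing the (1,3-thiazol-2-yl)amino group or from adding carbamoylmethyl. The compounds shown also leave open how a simple amine or a carboxylic acid on the same carbon would behave in this assay.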